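The compounds below may be only part of what the source reports. "The series", "measured", "known", "first", "only" and "open" are said of these compounds alone.

Compound 2 `O=C(C1=C(Nc2ccc(Br)cc2)C(=O)N(CCCn2ccnc2)C1c1ccc(Br)cc1)c1ccccc1` gives 22200 nM in a functional assay on A549 cells (Homo sapiens) for antiproliferative activity, read by MTT assay, with a stated time of 72 h; on this read-out lower numbers stand for stronger inhibition and higher numbers for weaker inhibition. Its only measured companion, compound 1 `O=C(C1=C(Nc2ccccc2)C(=O)N(CCCn2ccnc2)C1c1ccc(Br)cc1)c1ccccc1`, gives 24100 nM in this assay, and the two numbers sit within the scatter of each other. Within the data shown here, the single step known so far, a 1.1-fold lower number from compound 1 to compound 2 (0.04 log units; within the scatter), was the bromo for hydrogen swap on the same aromatic ring. Compound 3 `O=C(C1=C(Nc2ccc(Cl)cc2)C(=O)N(CCCn2ccnc2)C1c1ccc(Br)cc1)c1ccccc1` differs from compound 2 by chloro in place of bromo on an aromatic carbon. Among the measured compounds shown here, with the one comparable step lying within the scatter, no step beyond the scatter is expected in this assay, and compound 3 is estimated at 22000 nM, ranging from 11000 nM to 45000 nM. The expected step is a 1.0-fold lower number from compound 2 to compound 3 (0.00 log units; within the scatter).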

Compound 3, half-maximal inhibitory concentration: 30000 nM
Estimate against measurement, compound 3: 1.4-fold (0.13 log units) below, within the range that was stated.
By their numbers in this assay, from the lowest: compounds 2, 1 and 3 (each within the scatter of the next).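

In this assay the swap of 4-bromophenyl to 4-chlorophenyl gives a 1.4-fold higher number from compound 2 to compound 3 (0.13 log units; within the scatter) and chloro in place of hydrogen gives a 1.2-fold higher number from compound 1 to compound 3 (0.10 log units; within the scatter). This position has now carried hydrogen, bromo and chloro, and all three compounds sit within the scatter of one another. No measured evidence is available to explain these numbers. From the compounds shown here alone, whether an amine or a carboxylic acid at this position would give a step beyond the scatter stays open. Going by these compounds, the rest of the shared core is the same in all three compounds, so the outcome of changes there is also open.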